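Chloro in Place of Methylsulfanyl on a Ribose-Bearing Core

A few compounds are considered here, and "the series" means these few. Any claim that something is new, unique, unknown or untested is made for them only; others in the source may bear on it.

This comparison rests on a functional assay on KB cells (Homo sapiens) for cytotoxicity; a higher number here means that more compound is needed for the effect, a lower number that less compound is needed. Compound 1, `Nc1cc(Cl)c2nc[nH]c2n1`, gives 1 ug/mL in this assay. Compound 2, `CSc1cc(N)nc2c1ncn2[C@@H]1O[C@H](CO)[C@@H](O)[C@H]1O`, differs from compound 1 in more than one place, so the two values can only be set side by side. For compound 2 only a limit of this assay is known, > 22 ug/mL. For the measured compounds named here, the single piece of evidence is the limit of > 22 ug/mL in this assay, at which 1 of the 2 values shown sits. Compound 3, `Nc1cc(Cl)c2ncn([C@@H]3O[C@H](CO)[C@@H](O)[C@H]3O)c2n1`, has not yet been measured; it differs from compound 2 by chloro in place of methylsulfanyl on an aromatic carbon. Going by the values given here, no measured pair shows this change alone, so its size is not known from the data. Compound 3 is expected to move toward lower concentration by a step of an at least 3.6-fold lower number from compound 2 to compound 3 (0.56 log units; beyond the scatter), beyond the usual scatter. Compound 3 is estimated at 6 ug/mL, within a range from 1 ug/mL to 30 ug/mL.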

Compound 3, concentration for half-maximal effect: > 22 ug/mL
Compound 3: only a limit was reported; the forecaster's own chance of this, stated with the estimate: 40%; middle value at least 3.6-fold (0.56 log units) from the limit.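

No step can be read between compound 2 and compound 3, since both values stop at the same limit of the assay rather than giving a number: the limit of > 22 ug/mL in this assay, at which 2 of the 3 values shown sit.

Going by these compounds, whether chloro in place of methylsulfanyl on an aromatic carbon changes the concentration needed at all, and by how much, stays open.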